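Nitro Group Enters Where Chlorine Left

A few compounds are considered here, and "the series" means these few. Any claim that something is new, unique, unknown or untested is made for them only; others in the source may bear on it.

Measured so far:
Compound 1, `CC1=C(C(=O)Nc2ccc(F)cc2)C(c2ccc(Cl)cc2)n2c(s/c(=C/c3ccc(Br)cc3)c2=O)=N1`: 35%
Compound 2, `CC1=C(C(=O)Nc2ccc(F)cc2)C(c2ccc(Cl)cc2)n2c(s/c(=C/c3ccccc3Cl)c2=O)=N1`: 16%
Compound 3, `CC1=C(C(=O)Nc2ccc(F)cc2)C(c2ccc(Cl)cc2)n2c(s/c(=C/c3ccc(Cl)cc3Cl)c2=O)=N1`: 14%

All three were tested in a functional assay on the whole organism (strain albino) for inhibition, with Rattus norvegicus as the target, read by paw edema, with stated times of 1 h and 3 h, at a dose of 25 mg/kg by the oral route; a higher number here means more inhibition at the dose given (going by the name of the read-out), a lower number less inhibition. Compound 3 gives the lowest of the three numbers; compound 2 sits within the scatter of it, while compound 1 stands clearly higher. Compound 4, `CC1=C(C(=O)Nc2ccc(F)cc2)C(c2ccc(Cl)cc2)n2c(s/c(=C/c3ccccc3[N+](=O)[O-])c2=O)=N1`, is not yet measured and differs from compound 3 in one place: 2-nitrophenyl in place of 2,4-dichlorophenyl on a double-bonded chain carbon bound to an aromatic carbon. The steps that changed the same ring are a number 19 percentage points lower from compound 1 to compound 2 (beyond the scatter), a number 21 percentage points lower from compound 1 to compound 3 (beyond the scatter) and a number 2 percentage points lower from compound 2 to compound 3 (within the scatter). Within the data shown here, no measured step involves a nitro group, so the direction is open. This change is expected to give a step of a number 4 percentage points higher from compound 3 to compound 4 (within the scatter), within the scatter. Compound 4 is therefore estimated at 18%, between 5% and 35%.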

Compound 4, a percentage reported as inhibition, in the whole organism at one dose (the size of the read-out at that dose, not a potency): 16%
Compound 4: middle estimate off by 2 percentage points, on the high side; the range from low to high includes it.
By their numbers in this assay, from the lowest: compounds 3, 2 and 4 (each within the scatter of the next); then compound 1.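

Swapping chloro for nitro on this ring gives no change at the digits printed from compound 2 to compound 4 (within the scatter), and replacing 2,4-dichlorophenyl with 2-nitrophenyl gives a number 2 percentage points higher from compound 3 to compound 4 (within the scatter). A nitro group therefore does not set itself apart from the chlorinated rings at this place. Replacing 4-bromophenyl with 2-nitrophenyl gives a number 19 percentage points lower from compound 1 to compound 4 (beyond the scatter), so the gap to the bromo compound remains. Nothing available explains why these groups give such similar numbers. Still open, from the compounds shown here alone, is whether a nitro group in place of the bromine of compound 1, or an amine or a carboxylic acid on this ring, would give a higher number.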